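The source may hold more compounds than are shown below. What is called first, only, known or untested is meant among the compounds shown, and "the series" means these compounds.

Compound 1 `O=C(CCCCCCc1ccccc1C(=O)O)c1ncc(-c2ccccn2)o1` and compound 2 `O=C(O)c1cccc(CCCCCCC(=O)c2ncc(-c3ccccn3)o2)c1` share the same core and the same saturated chain, and differ only in where the carboxylic acid sits on the terminal phenyl ring. In an assay for inhibition of Fatty-acid amide hydrolase 1 (Rattus norvegicus) (a lower number here means a stronger inhibitor, a higher number a weaker inhibitor), compound 1 gives only a limit, > 600 nM. In this assay compound 2 likewise gives only a limit, > 600 nM. Going by the values given here, the single measured step, a step that the two limits leave unreadable from compound 1 to compound 2, therefore cannot be read in either direction, because both values rest at the limit of > 600 nM in this assay, at which 2 of the 2 values shown sit. Compound 3 `O=C(O)c1ccc(CCCCCCC(=O)c2ncc(-c3ccccn3)o2)cc1` has not yet been measured; it differs from compound 2 by 4-carboxyphenyl in place of 3-carboxyphenyl on a saturated chain carbon, six bonds along the chain from a carbonyl carbon. Among the compounds with values here, no measured step bears on this change, and nothing in the two known values points away from the limit. The step that the limit leaves unreadable from compound 2 to compound 3 is therefore expected to be nothing beyond the scatter. Compound 3 is estimated at 1500 nM, within a range from 500 nM to 5000 nM.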

Compound 3, inhibition constant: > 600 nM
Compound 3 was reported as a limit; the forecaster's own chance of this, stated with the estimate: 80%; the middle value is on the limit's open side.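

In this assay, going by these compounds alone, compound 3 also gives only a limit, so no step among compound 1, compound 2 and compound 3 can be read: the limit of > 600 nM in this assay, at which 3 of the 3 values shown sit. The compounds shown leave open whether 2-carboxyphenyl, 3-carboxyphenyl and 4-carboxyphenyl differ at all in this assay.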